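The compounds below may be only part of what the source reports. "The series", "measured", "known", "first", "only" and "open" are said of these compounds alone.

Measured in a functional assay on the whole organism with Scenedesmus acutus as the target (on this read-out higher numbers stand for weaker inhibition and lower numbers for stronger inhibition), so far:
Compound 1 `O=C(O)c1cc(N2C(=O)C3=C(CCCC3)C2=O)c(F)cc1Cl` gives 759 nM
Compound 2 `COC(=O)c1cc(N2C(=O)C3=C(CCCC3)C2=O)ccc1Cl` gives 2000 nM
Compound 3 `COC(=O)c1cc(N2C(=O)C3=C(CCCC3)C2=O)c(F)cc1Cl` gives 110 nM

In this assay compound 2 has 2000 nM as its number, the highest of the three and so the weakest inhibition here. Compound 4 `CC(C)COC(=O)c1cc(N2C(=O)C3=C(CCCC3)C2=O)ccc1Cl` differs from it only in the ester. The change is isopropyl in place of hydrogen on a saturated chain carbon bound to an oxygen next to a carbonyl group and it reads as methoxycarbonyl to isobutoxycarbonyl.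

Among the measured compounds shown here, one measured step touches the same oxygen: a 6.9-fold lower number from compound 1 to compound 3 (0.84 log units; beyond the scatter) and this modest step is methyl in place of hydrogen on an oxygen next to a carbonyl group. It starts from an acid, however, not from an ester. The large step of an 18-fold lower number from compound 2 to compound 3 (1.26 log units; beyond the scatter) is a fluoro change on an aromatic carbon and says little about the ester. For the measured compounds named here, no measured step lengthens the ester chain, so the precedent is loose. In this assay a small downward change is expected, estimated as a 1.7-fold lower number from compound 2 to compound 4 (0.22 log units; within the scatter) and possibly no real change at all. Compound 4 is estimated at 1200 nM with 300 nM to 4500 nM as the expected range.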

Compound 4, half-maximal inhibitory concentration: 759 nM
The estimate for compound 4 lay 1.6-fold (0.20 log units) above the measured number, and the stated range covers the measured number.
By their numbers in this assay, from the lowest: compound 3; then compounds 1 and 4 (each within the scatter of the next); then compound 2.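

In this assay the change from methoxycarbonyl to isobutoxycarbonyl gives a 2.6-fold lower number from compound 2 to compound 4 (0.42 log units; beyond the scatter) and so counts as a real change rather than no change at all. The earlier step at this oxygen started from an acid, whereas this one compares two esters directly and shows that isopropyl in place of hydrogen on the saturated chain carbon bound to this oxygen is accompanied by stronger inhibition, not weaker. No measurement shown here explains this gain.

The compounds shown leave open whether a longer chain in the ester, such as hexyl, or a benzyl ester would move the number further, or whether the trend stops at isobutyl. They also leave open whether the isobutoxycarbonyl group and the fluoro on the aromatic carbon would add up when present together.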